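From methylsulfanyl to butoxy under assay limits

The source may report more compounds than this note shows. Statements on the series, on what has been measured and on what is new or still open speak of the compounds shown alone.

Of the compounds shown here, three sharing one core have been tested in an ADME assay on CCRF-HSB-2 cells (Homo sapiens) for cytotoxicity, with a stated time of 7 days (a higher number here means that more compound is tolerated, a lower number that less compound is tolerated), and none has yet given an exact value. Compound 1 `COCCOc1nc(N)nc2c1ncn2/C=C1/CC1(CO)CO`, carrying 2-methoxyethoxy, reads > 20000 nM, which is a limit of the assay. Compound 2 `Nc1nc(NCc2ccccc2)c2ncn(/C=C3/CC3(CO)CO)c2n1`, carrying benzylamino, reads > 20000 nM, also a limit. Compound 3 `CSc1nc(N)nc2c1ncn2/C=C1/CC1(CO)CO`, carrying methylsulfanyl, reads > 100000 nM, likewise a limit, so its true position is not known.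

Compound 4 `CCCCOc1nc(N)nc2c1ncn2/C=C1/CC1(CO)CO` departs from compound 3 at a single place, on an aromatic carbon: butoxy in place of methylsulfanyl on an aromatic carbon.

Three measured changes at this same place bear on the comparison, and none supplies a size. Within the data shown here, the first is a step that the two limits leave unreadable from compound 1 to compound 3. The second is a step that the two limits leave unreadable from compound 2 to compound 3. The third is a step that the two limits leave unreadable from compound 1 to compound 2.

The closest neighbour of compound 4 is compound 1, since butoxy and 2-methoxyethoxy are both ethers, and its reading in this assay is > 20000 nM, a limit. A modest move toward less compound being tolerated is therefore expected, with low confidence, and another limit is the likeliest report. The expected change is an at least 2.5-fold lower number from compound 3 to compound 4 (0.39 log units; beyond the scatter). For compound 4 the estimate in this assay is 40000 nM, with an expected range of 12000 nM to 100000 nM.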

Compound 4, half-maximal cytotoxic concentration: > 20000 nM
Compound 4: no number, only a limit; the forecaster's own chance of this, stated with the estimate: 85%; the middle value lies beyond the limit too.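

In this assay, among these compounds, compound 4 reads > 20000 nM, which is a limit of the assay, so no step linking it to compound 1, compound 2 or compound 3 can be read. The compounds shown leave open where each truly stands, and whether butoxy, methylsulfanyl, benzylamino or 2-methoxyethoxy changes how much compound is tolerated at all.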